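Benzofuran for thiophene on a compound at the assay limit

The source may hold more compounds than are shown below. What is called first, only, known or untested is meant among the compounds shown, and "the series" means these compounds.

Compound 1 `CNc1ncnc2c1c(-c1cc3ccccc3o1)cn2[C@@H]1O[C@H](CO)[C@@H](O)[C@H]1O`: > 20000 nM (a limit)
Compound 2 `CN(C)c1ncnc2c1c(-c1cc3ccccc3o1)cn2[C@@H]1O[C@H](CO)[C@@H](O)[C@H]1O`: > 20000 nM (a limit)
Compound 3 `Cc1ncnc2c1c(-c1cccs1)cn2[C@@H]1O[C@H](CO)[C@@H](O)[C@H]1O`: > 20000 nM (a limit)

All three compounds were tested in a functional assay on CCRF-CEM cells (Homo sapiens), read by MTT assay, with a stated time of 72 h; a lower number here means a stronger inhibitor, a higher number a weaker inhibitor. None of them gave an actual number, and the evidence so far is the limit of > 20000 nM in this assay, at which 3 of the 3 values shown sit. Going by these compounds, compound 3 therefore stands only at a limit, > 20000 nM, so its true position is unknown.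

Compound 4 `Cc1ncnc2c1c(-c1cc3ccccc3o1)cn2[C@@H]1O[C@H](CO)[C@@H](O)[C@H]1O` differs from compound 3 by one change, (1-benzofuran-2-yl in place of thiophen-2-yl on an aromatic carbon). In words, 1-benzofuran-2-yl takes the place of thiophen-2-yl on an aromatic carbon.

Among the measured compounds shown here, the only measured step nearby is a step that the two limits leave unreadable from compound 1 to compound 2, and it gives no size to build on. Compound 1 and compound 2 do carry the same 1-benzofuran-2-yl group as compound 4, but they differ from it elsewhere. Compound 2 still reads > 20000 nM, which is a limit. Nothing measured here shows this group bringing a readable inhibition, so no clear step in either direction is expected, and another limit is the likeliest result.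

The expected step is a number no higher from compound 3 to compound 4 (the limit leaves the size open). For compound 4 the estimated value is 20000 nM, with an expected range from 7000 nM to 40000 nM.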

Compound 4, half-maximal inhibitory concentration: 17300 nM
Estimate against measurement, compound 4: 1.2-fold (0.06 log units) above; the measured number falls inside the stated range.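

In this assay, compound 4 is the only compound shown that gives an actual number rather than a limit, so a compound carrying 1-benzofuran-2-yl can be read in this test, though the others stay out of reach: the limit of > 20000 nM in this assay, at which 3 of the 4 values shown sit. Placing 1-benzofuran-2-yl where thiophen-2-yl stood gives an at least 1.1-fold lower number from compound 3 to compound 4 (0.06 log units; that floor lies within the scatter), and this is only a floor, so the swap may do little or much more than that. Methyl in place of dimethylamino gives an at least 1.1-fold lower number from compound 2 to compound 4 (0.06 log units; that floor lies within the scatter), and methyl in place of methylamino gives an at least 1.1-fold lower number from compound 1 to compound 4 (0.06 log units; that floor lies within the scatter); these are floors of the same kind, while the step from compound 1 to compound 2 cannot be read.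

Going by these compounds, the true size of all three steps stays open, since each starts from a compound known only as a limit. Also open, on these data alone, is whether a plain amino group or a methoxy group on the carbon that carries methyl, or a furan-2-yl group in place of 1-benzofuran-2-yl, would give a number clearly lower than that of compound 4.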